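Swapping an aromatic ring for a saturated one on the amide

The compounds below may be only part of what the source reports. "The series", "measured", "known", "first", "only" and "open" are said of these compounds alone.

Measured compounds:
- Compound 1, `O=C1C(=O)N(Cc2cn(CC(=O)N3CCOCC3)nn2)c2c(Cl)ccc(Cl)c21`: 113000 nM
- Compound 2, `O=C(Cn1cc(CN2C(=O)C(=O)c3c(Cl)ccc(Cl)c32)nn1)Nc1ccccc1`: 27000 nM
- Compound 3, `CC(C)(C)OC(=O)N1CCN(C(=O)Cn2cc(CN3C(=O)C(=O)c4c(Cl)ccc(Cl)c43)nn2)CC1`: > 128000 nM (a limit of the assay, not a number)

All three share a core carrying two chlorines and a triazole, and differ only in the amide attached to the triazole. In a functional assay on SW780 cells (Homo sapiens) for inhibition, read by CCK-8 assay, with a stated time of 72 h (on this read-out higher numbers stand for weaker inhibition and lower numbers for stronger inhibition), compound 2 gives the lowest of the two numbers; the step of a 4.2-fold lower number from compound 1 to compound 2 (0.62 log units; beyond the scatter) is modest but beyond the scatter. For compound 3 the assay reports only a limit, (the limit of > 128000 nM in this assay, at which 1 of the 3 values shown sits).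

Compound 4, `O=C(Cn1cc(CN2C(=O)C(=O)c3c(Cl)ccc(Cl)c32)nn1)NC1CCCCC1`, is not yet measured. It differs from compound 2 by cyclohexyl in place of phenyl on an amide-type nitrogen. Among the measured compounds shown here, none of the measured steps changes this part of the molecule in the same way, since the only measured step replaces the whole group on the carbonyl carbon rather than the ring on the amide nitrogen. What can be said is that the amide hydrogen of compound 2 is kept in compound 4. The change is therefore expected to move the number little, if at all, with a slight lean toward a higher number. Compound 4 is estimated at 40000 nM, between 12000 nM and 128000 nM, which amounts to an expected step of a 1.5-fold higher number from compound 2 to compound 4 (0.17 log units; within the scatter).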

Compound 4, half-maximal inhibitory concentration: 93300 nM
The estimate for compound 4 lay 2.3-fold (0.37 log units) below the measured number; measured number inside the range.
By their numbers in this assay, from the lowest: compound 2; then compounds 4 and 1 (each within the scatter of the next). At a limit, above all of these: compound 3.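

On the amide nitrogen, the kind of ring matters and not only its size: with the amide hydrogen kept and the same count of ring atoms, cyclohexyl in place of phenyl in this assay gives a clear change (a 3.5-fold higher number from compound 2 to compound 4 (0.54 log units; beyond the scatter)). The earlier step had replaced the whole group on the carbonyl carbon, so it could not separate the aromatic ring from the amide hydrogen. Compound 4 now does this, since cyclohexylamino in place of morpholin-4-yl leaves the number within the scatter (a 1.2-fold lower number from compound 1 to compound 4 (0.08 log units; within the scatter)), and so keeping the amide hydrogen with a saturated ring does not match compound 2.

Still open, as far as these compounds go, is whether a benzyl group, a pyridine ring or a phenyl ring bearing a methoxy group would bring the number lower than in compound 2. Nothing shown here explains the effect of the aromatic ring.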